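Changing the aryl group on an aromatic nitrogen

This account rests on a few compounds, and the source may have more. Where it says the series, first, only, none or still open, it means among the compounds named here.

In a functional assay on A549 cells (Homo sapiens) for antiproliferative activity, read by MTT assay, with a stated time of 48 h (on this read-out lower numbers stand for stronger inhibition and higher numbers for weaker inhibition), compound 3 `Cc1ccccc1-n1nncc1CN1C(=O)C2(C(C#N)=C(N)Oc3c(N)cc4nc5ccccc5nc4c32)c2ccccc21` gives 31700 nM, the lowest of the two numbers in hand. Its nearest neighbour, compound 2 `N#CC1=C(N)Oc2c(c3nc4ccccc4nc3c3ccccc23)C12C(=O)N(Cc1cnnn1-c1ccccc1Cl)c1ccccc12`, gives 42600 nM, a gap that lies within the scatter. Compound 1 `N#CC1=C(N)Oc2c(c3nc4ccccc4nc3c3ccccc23)C12C(=O)N(Cc1cnnn1-c1ccc(Cl)cc1)c1ccccc12` gives only the limit > 50000 nM, which is a limit of this assay (the limit of > 50000 nM in this assay, at which 1 of the 3 values shown sits). Compound 4 `Cc1ccc(-n2nncc2CN2C(=O)C3(C(C#N)=C(N)Oc4c(N)cc5nc6ccccc6nc5c43)c3ccccc32)cc1Cl` differs from compound 3 by 3-chloro-4-methylphenyl in place of 2-methylphenyl on an aromatic nitrogen. Going by the values given here, the one measured step at this position, an at least 1.1-fold lower number from compound 1 to compound 2 (0.06 log units; that floor lies within the scatter), stays within the scatter, and the gap between compound 2 and compound 3 does too. No step beyond the scatter is therefore expected, a 1.0-fold higher number from compound 3 to compound 4 (0.00 log units; within the scatter). Compound 4 is estimated at 32000 nM, with a range from 12000 nM to 90000 nM.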

Compound 4, half-maximal inhibitory concentration: 11800 nM
For compound 4 the middle estimate is 2.7-fold (0.43 log units) above the measured one; the whole stated range lies above it.
By their numbers in this assay, from the lowest: compound 4; then compounds 3 and 2 (each within the scatter of the next). At a limit, above all of these: compound 1.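

In this assay, replacing 2-methylphenyl with 3-chloro-4-methylphenyl on the aromatic nitrogen gives a 2.7-fold lower number from compound 3 to compound 4 (0.43 log units; beyond the scatter). Going by these compounds alone, this is the first step at this position to lie beyond the scatter, so the aryl group here can shift the number modestly. Nothing given here accounts for the step.

The compounds shown do not separate the contribution of the chlorine from that of the methyl group in the entering aryl group. Also open, going by these compounds, is how an amine or a carboxylic acid on this aryl group would read.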